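Bromo Added to a Sulfonamide in a Cell Binding Test

The compounds below may be only part of what the source reports. "The series", "measured", "known", "first", "only" and "open" are said of these compounds alone.

Measured compounds:
compound 1 `O=C(c1ccccc1)c1cccc(NS(=O)(=O)c2ccccc2)c1`: 4%
compound 2 `Cc1ccc(S(=O)(=O)Nc2ccc(C(=O)c3ccccc3)cc2)cc1`: 35%

In an assay on CHO cells for binding affinity to integrin alpha-1 (Homo sapiens), read by WST assay, with a stated time of 2 h, tested at 50 uM (on this read-out lower numbers stand for less inhibition and higher numbers for more inhibition at the one concentration tested (going by the name of the read-out)), compound 1 gives 4%, the lowest of the two numbers. Compound 2 gives 35%, which lies apart from compound 1 by more than the usual scatter. The two structures differ in more than one place, so the pair shows only that gap, nothing about a single change.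

Compound 3 `O=C(c1ccccc1)c1cccc(NS(=O)(=O)c2ccc(Br)cc2)c1` is not yet measured. It differs from compound 1 by bromo in place of hydrogen on an aromatic carbon. Among the measured compounds shown here, no measured pair shows this change, so only a small upward step is expected, a number 8 percentage points higher from compound 1 to compound 3 (within the scatter), likely within the scatter. Compound 3 is estimated at 12%, ranging from 0% to 32%.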

Compound 3, a percentage reported as inhibition, at one concentration (the size of the read-out at that concentration, not a potency): 92%
The estimate for compound 3 lay 80 percentage points below the measured number, and the stated range ends below it.
By their numbers in this assay, from the lowest: compound 1; then compound 2; then compound 3.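

Changing phenyl to 4-bromophenyl adds only one heavy atom, yet in this assay it gives a number 88 percentage points higher from compound 1 to compound 3 (beyond the scatter) and is the only single change shown here. This place on the ring, para to a large group, is therefore far from indifferent to what it carries, at least for bromo. Nothing available explains why the step is so large.

Going by these compounds, whether chloro, an amine or a carboxylic acid at the same place would give a similar number remains open. So does whether bromo would have a similar effect on the other ring.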